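A few compounds are considered here, and "the series" means these few. Any claim that something is new, unique, unknown or untested is made for them only; others in the source may bear on it.

Compound 1 `CCN(CC)c1ccc(-c2ccc(C(C)=O)cc2)nn1` gives the limit > 25000 nM
Compound 2 `CN1CCN(c2ccc(-c3cccc(C(F)(F)F)c3)nn2)CC1` gives the limit > 25000 nM
Compound 3 `CCCCOc1ccc(-c2cccc(C#N)c2)nn1` gives the limit > 25000 nM

These readings come from a functional assay on PC-3 cells (Homo sapiens) for antiproliferative activity, with a stated time of 48 h; on this read-out higher numbers stand for weaker inhibition and lower numbers for stronger inhibition. Compound 2 has no number here, only a limit, and the two other compounds also have only limits. The three compounds therefore stand together: the limit of > 25000 nM in this assay, at which 3 of the 3 values shown sit.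

The step followed here leads from compound 2 to compound 4 `FC(F)(F)c1cccc(-c2ccc(Oc3ccccc3)nn2)c1`, which has not yet been measured. The change is phenoxy in place of 4-methylpiperazin-1-yl on an aromatic carbon. In words, phenoxy stands in place of 4-methylpiperazin-1-yl on an aromatic carbon, while the rest of the structure stays the same.

Going by the values given here, no pair of measured compounds differs in one place only, so the data offer no step by which to size this change. The expectation rests only on the shared reading of the three compounds, (the limit of > 25000 nM in this assay, at which 3 of the 3 values shown sit). No change beyond the scatter is expected, and compound 4 may well return a limit too. If a number does appear, it is expected to lean towards stronger inhibition. In this assay the expected step is an at least 1.1-fold lower number from compound 2 to compound 4 (0.05 log units; that floor lies within the scatter). Compound 4 is estimated at 22000 nM, with an expected range of 7000 nM to 30000 nM.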

Compound 4, half-maximal inhibitory concentration: > 25000 nM
Compound 4: no number, only a limit; the forecaster's own chance of this, stated with the estimate: 65%; at least 1.1-fold (0.05 log units) between middle value and limit.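

In this assay compound 4 gives only a limit, > 25000 nM. Compound 2 also has only a limit, so the step from compound 2 to compound 4 cannot be read. The compounds shown leave open whether phenoxy in place of 4-methylpiperazin-1-yl changes the inhibition at all, and how far any of them lies from the limit.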